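A Third Methoxy on the Core of Compound 3

A few compounds are considered here, and "the series" means these few. Any claim that something is new, unique, unknown or untested is made for them only; others in the source may bear on it.

Compound 1 `CC(=O)N1N=C(c2cccc([N+](=O)[O-])c2)CC1c1ccccc1` gives 9920 nM in a functional assay on OVCAR cells (Homo sapiens) for cytotoxicity, read by sulforhodamine B assay, with a stated time of 48 h; a higher number here means a weaker inhibitor, a lower number a stronger inhibitor. Compound 2 `COc1ccc(C2CC(c3cccc([N+](=O)[O-])c3)=NN2C(C)=O)cc1` carries methoxy in place of hydrogen on an aromatic carbon, and in this assay compound 2 gives 8760 nM; the step is a 1.1-fold lower number from compound 1 to compound 2 (0.05 log units; within the scatter). Compound 3 `COc1ccc(C2CC(c3ccco3)=NN2C(C)=O)cc1OC` rests on another core; the difference between the core of compound 1 and that of compound 3 is not broken down here. In this assay compound 3 gives 31200 nM, the highest of the three numbers. Compound 4 `COc1cc(OC)c(C2CC(c3ccco3)=NN2C(C)=O)cc1OC` differs from compound 3 by methoxy in place of hydrogen on an aromatic carbon. This is the same kind of change as that from compound 1 to compound 2, though here the place is ortho to a large group, meta to a methoxy group and para to a methoxy group, whereas in compound 2 it is para to a large group. Compound 4 is expected to move only a little from its parent, a 1.2-fold lower number from compound 3 to compound 4 (0.06 log units; within the scatter), because the earlier step was a 1.1-fold lower number from compound 1 to compound 2 (0.05 log units; within the scatter). Compound 4 is therefore estimated at 27000 nM in this assay, between 12000 nM and 60000 nM.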

Compound 4, half-maximal inhibitory concentration: 6760 nM
Compound 4: the middle estimate sits 4.0-fold (0.60 log units) above what was measured; measured number outside the range, below it.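

In this assay, putting methoxy in place of hydrogen gave a 4.6-fold lower number from compound 3 to compound 4 (0.66 log units; beyond the scatter), and this step does not match the earlier one: the same change on two cores in this assay, a 1.1-fold lower number (0.05 log units; within the scatter) from compound 1 to compound 2 and a 4.6-fold lower number (0.66 log units; beyond the scatter) from compound 3 to compound 4, 4.1-fold (0.61 log units) apart, beyond the scatter of two such steps The size of the change on the core of compound 1 therefore did not carry over to the core of compound 3. Among these compounds, this does not show whether the core or the place accounts for the gap, as the new methoxy stands ortho to a large group, meta to a methoxy group and para to a methoxy group, unlike the one in compound 2.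

The compounds shown leave open how a hydroxyl, an amine or an ethoxy group in that same place would compare with methoxy. They also leave open what methoxy in that place would do on the core of compound 1.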